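A Hydroxyphenyl for a Methoxyphenyl on the Shared Core

The compounds below may be only part of what the source reports. "The series", "measured", "known", "first", "only" and "open" are said of these compounds alone.

Of the compounds shown here, three built on one core have been tested in a functional assay on T47D cells (Homo sapiens) for cytotoxicity, read by CCK-8 assay and cell counting, with a stated time of 72 h; a lower number here means a stronger inhibitor, a higher number a weaker inhibitor. Compound 1 `COc1cc(OC)cc(-c2cc3ccccc3c(-c3cccc(O)c3)n2)c1` gives 760 nM and compound 2 `COc1cc(OC)cc(-c2cc3ccccc3c(-c3cccc(OC)c3)n2)c1` gives 1120 nM; between them the step is a 1.5-fold higher number from compound 1 to compound 2 (0.17 log units; within the scatter). Compound 3 `COc1cccc(-c2nc(-c3ccc(OC)c(OC)c3)cc3cc(C)ccc23)c1` gives 7860 nM, the highest number of the three, and its distance from both compound 1 and compound 2 lies beyond the scatter.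

Compound 4 `COc1ccc(-c2cc3cc(C)ccc3c(-c3ccc(O)cc3)n2)cc1OC` is not yet measured. It differs from compound 3 by 4-hydroxyphenyl in place of 3-methoxyphenyl on an aromatic carbon. For the measured compounds named here, only one measured step touches this change: a 1.5-fold higher number from compound 1 to compound 2 (0.17 log units; within the scatter), which put a methyl on a ring oxygen and stayed within the scatter. Going by the values given here, the change in compound 4 runs the other way, removing the methyl, but it also turns a 3-methoxyphenyl into a 4-hydroxyphenyl, a shift that no measured pair covers. Among the compounds with values here, on the one step in hand, the expected effect in this assay is a small lowering of the number, within the scatter, with added uncertainty from the shift of the oxygen. Compound 4 is therefore estimated at 5200 nM, in the range 1600 nM to 16000 nM, an expected step of a 1.5-fold lower number from compound 3 to compound 4 (0.18 log units; within the scatter).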

Compound 4, half-maximal inhibitory concentration: 4420 nM
For compound 4 the middle estimate is 1.2-fold (0.07 log units) above the measured one; low and high end bracket the measured number.
By their numbers in this assay, from the lowest: compounds 1 and 2 (each within the scatter of the next); then compounds 4 and 3 (each within the scatter of the next).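

In this assay, putting 4-hydroxyphenyl in place of 3-methoxyphenyl on the aromatic carbon next to the ring nitrogen gives a 1.8-fold lower number from compound 3 to compound 4 (0.25 log units; within the scatter). The earlier step at this place, a 1.5-fold higher number from compound 1 to compound 2 (0.17 log units; within the scatter), exchanged only a hydrogen for a methyl on an oxygen that stayed where it was, whereas the new step also changes where the oxygen sits on the phenyl ring, and it too stays within the scatter. On the core of compound 3, then, this position accepts both the loss of the methyl and the shift of the oxygen together without a readable change in the number, and nothing at hand speaks to why that is so.

As far as these compounds go, the step joins two changes in one, so the share of each stays unknown until 3-hydroxyphenyl and 4-methoxyphenyl can be read separately on the core of compound 3. From the compounds shown here alone, it also remains open whether a group of another kind on this phenyl ring, such as an amine, a carboxylic acid or a longer chain on the oxygen, would move the number beyond the scatter.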